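The compounds below may be only part of what the source reports. "The series", "measured", "known", "first", "only" and "open" are said of these compounds alone.

In a physicochemical assay for lipophilicity, at pH 7.4 (on this read-out lower numbers stand for lower lipophilicity and higher numbers for higher lipophilicity), compound 2 (`CCOc1ccc2c(c1)C(c1cnn(C)c1)=CN(C)C(=O)[C@@H]2C`) gives 4.1 and holds the higher of the two numbers, while compound 1 (`CCS(=O)(=O)c1ccc2c(c1)C(c1cnn(C)c1)=CN(C)C(=O)[C@@H]2C`) gives 2.8 on the same scale. Compound 3 (`CCOc1ccc2c(c1)C(c1cn[nH]c1)=CN(C)C(=O)[C@@H]2C`) differs from compound 2 by hydrogen in place of methyl on an aromatic nitrogen in a single change: hydrogen in place of methyl on an aromatic nitrogen. For the measured compounds named here, the only measured step, a number 1.30 log units higher from compound 1 to compound 2 (beyond the scatter) with ethoxy in place of ethylsulfonyl on an aromatic carbon, lies at another place and offers only a loose guide, so a much smaller, downward move is expected. The estimated move is a number 0.40 log units lower from compound 2 to compound 3 (beyond the scatter) and remains a tentative expectation. Compound 3 is estimated at 3.7 with an expected range from 3.2 to 4.1 in this assay.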

Compound 3, distribution coefficient: 3.4
Compound 3: middle estimate off by 0.30 log units, on the high side, within the range that was stated.
By their numbers in this assay, from the lowest: compound 1; then compound 3; then compound 2.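

In this assay, for the compounds shown here, the change from 1-methyl-1H-pyrazol-4-yl to 1H-pyrazol-4-yl gives a number 0.70 log units lower from compound 2 to compound 3 (beyond the scatter) and so shows that this aromatic nitrogen, unchanged between the earlier compounds, also moves the read-out beyond the scatter. This step is smaller than a number 1.30 log units higher from compound 1 to compound 2 (beyond the scatter) at the other place on the core. Nothing at hand explains the shift. The compounds shown leave open how an ethyl or a 2-aminoethyl group on this nitrogen would read. They also leave open whether the same swap would give a similar step with ethylsulfonyl in place of ethoxy.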